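Compound 2: bromo in place of amino

The source may report more compounds than this note shows. Statements on the series, on what has been measured and on what is new or still open speak of the compounds shown alone.

Three compounds sharing one core have numbers in a functional assay on CEM-SS cells (Homo sapiens) for cytotoxicity; a higher number here means a weaker inhibitor, a lower number a stronger inhibitor. Compound 1 `CC(C)(C)c1ccc(Cn2c(N)nc3cc(Cl)c(Cl)cc32)cc1` gives 27000 nM, compound 2 `Nc1nc2cc(Cl)c(Cl)cc2n1Cc1ccc([N+](=O)[O-])cc1` gives 32000 nM, and compound 3 `Nc1nc2cc(Cl)c(Cl)cc2n1Cc1ccc(F)cc1` gives 30000 nM. Compound 2 thus stands level with the other two, and the scatter allows no order among them. The steps that link them are all small: a 1.2-fold higher number from compound 1 to compound 2 (0.07 log units; within the scatter), a 1.1-fold higher number from compound 1 to compound 3 (0.05 log units; within the scatter) and a 1.1-fold lower number from compound 2 to compound 3 (0.03 log units; within the scatter). Each exchanges tert-butyl, nitro or fluoro on an aromatic carbon.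

The unmeasured compound 4 `O=[N+]([O-])c1ccc(Cn2c(Br)nc3cc(Cl)c(Cl)cc32)cc1` keeps the nitro group of compound 2 but changes another place: bromo in place of amino on an aromatic carbon. This puts bromo in place of amino on an aromatic carbon, between two ring nitrogen atoms. Going by the values given here, none of the measured steps touches that place, so the data hold no direct measure of this change. They bear on it only indirectly, as a sign that these three compounds sit close together whichever group they carry. Among the compounds with values here, with a 1.2-fold higher number from compound 1 to compound 2 (0.07 log units; within the scatter) and a 1.1-fold lower number from compound 2 to compound 3 (0.03 log units; within the scatter) as the only guide, no step beyond the scatter is expected in this assay, in either direction, though this expectation is loose. The estimated step is a 1.1-fold lower number from compound 2 to compound 4 (0.03 log units; within the scatter). Compound 4 is expected at 30000 nM, with an estimated range of 10000 nM to 90000 nM.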

Compound 4, half-maximal inhibitory concentration: > 100000 nM
Compound 4: a limit, no number (the forecaster's own chance of this, stated with the estimate: 20%); middle value at least 3.3-fold (0.52 log units) away from the limit.
By their numbers in this assay, from the lowest: compounds 1, 3 and 2 (each within the scatter of the next). At a limit, above all of these: compound 4.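

In this assay compound 4 gives > 100000 nM, which is a limit of the assay and not a number. Bromo in place of amino gives an at least 3.1-fold higher number from compound 2 to compound 4 (0.49 log units; beyond the scatter), so this carbon between two ring nitrogen atoms is a place where one exchange carries the number beyond the scatter, whereas tert-butyl, nitro and fluoro on the other aromatic carbon left the numbers level. Only a lower bound on the size of this step can be read, and how much weaker compound 4 is stays unknown: the limit of > 100000 nM in this assay, at which 1 of the 4 values shown sits.

The compounds shown leave open whether the same exchange has the same outcome with tert-butyl or fluoro in place of nitro, since only the nitro compound carries bromo here. They also cannot separate the departure of amino, with its hydrogen-bond donor and acceptor, from the arrival of bromo, and a methylamino group or a methyl group on the same carbon would bear on that question.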